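The compounds below may be only part of what the source reports. "The series", "measured", "known", "first", "only" and "open" are said of these compounds alone.

Measured compounds:
Compound 1, `CC1CCN(Cc2ccc3nc(NC(=O)N/N=C/c4cn(Cc5cccc(Cl)c5)c5ccccc45)sc3c2)CC1` — 2110 nM
Compound 2, `Cc1ccc(Cn2cc(/C=N/NC(=O)Nc3nc4ccc(CN(C)C)cc4s3)c3ccccc32)cc1` — 1220 nM
Compound 3, `CCN(CC)Cc1ccc2nc(NC(=O)N/N=C/c3cn(Cc4cccc(Cl)c4)c4ccccc34)sc2c1` — 2050 nM

In a functional assay on MDA-MB-231 cells (Homo sapiens) for cytotoxicity, read by MTT assay, with a stated time of 72 h (on this read-out lower numbers stand for stronger inhibition and higher numbers for weaker inhibition), compound 3 gives 2050 nM, which places it second highest of the three numbers shown; compound 1 sits nearest to it and compound 2 furthest, yet both gaps lie within the scatter. Within the data shown here, the only step between compounds that differ in one place is a 1.0-fold lower number from compound 1 to compound 3 (0.01 log units; within the scatter), and it concerns the amine on the saturated chain carbon, not the benzyl ring.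

Compound 4, `CCN(CC)Cc1ccc2nc(NC(=O)N/N=C/c3cn(Cc4ccc(Cl)c(Cl)c4)c4ccccc34)sc2c1`, has not yet been measured in this assay. It differs from compound 3 by chloro in place of hydrogen on an aromatic carbon, so that the 3-chlorobenzyl becomes a 3,4-dichlorobenzyl. Among the measured compounds shown here, no measured step touches this ring: compound 2 carries a 4-methylbenzyl group together with a dimethylamino group, so its value and that of compound 3 differ in two places and cannot be read as one step. With nothing in the data to anchor a direction, the expected step of a 1.1-fold lower number from compound 3 to compound 4 (0.06 log units; within the scatter) is estimated to lie within the scatter. Compound 4 is therefore expected to give about 1800 nM in this assay, within 800 nM to 4500 nM.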

Compound 4, half-maximal inhibitory concentration: 4490 nM
For compound 4 the middle estimate is 2.5-fold (0.40 log units) below the measured one; the range from low to high includes it.
By their numbers in this assay, from the lowest: compounds 2, 3 and 1 (each within the scatter of the next); then compound 4.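

In this assay, the benzyl ring turns out to be a place where one added atom can move the number: the change from 3-chlorobenzyl to 3,4-dichlorobenzyl gives a 2.2-fold higher number from compound 3 to compound 4 (0.34 log units; beyond the scatter). This is the first single change shown to go beyond the scatter, whereas the amine change, a 1.0-fold lower number from compound 1 to compound 3 (0.01 log units; within the scatter), stayed within it. The new chloro group stands ortho to the existing chloro group and para to a large group, and at this place it weakens inhibition modestly. Nothing in the data accounts for this step.

Going by these compounds, it remains open whether a 4-chlorobenzyl group, with no chloro group at the 3 position, or a 3,4-dimethoxybenzyl group would give a similar step. On these data alone, it is also open whether the same step would appear with 4-methylpiperidin-1-yl in place of diethylamino.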